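Replacing the nitro of compound 2 with methylamino

A few compounds are considered here, and "the series" means these few. Any claim that something is new, unique, unknown or untested is made for them only; others in the source may bear on it.

Among the compounds with values here, compound 2 `O=[N+]([O-])c1cc(CNCCCNC2CCCCC2)cc(CNCCCNC2CCCCC2)c1` gives 147 nM in an assay on CHO cells for displacement of a labelled ligand from C-X-C chemokine receptor type 4 (Homo sapiens), with a stated time of 40 min (on this read-out lower numbers stand for stronger inhibition and higher numbers for weaker inhibition), the lowest of the two numbers so far; compound 1 `c1c(CNCCCNC2CCCCC2)cc(CNCCCNC2CCCCC2)cc1CNCCCNC1CCCCC1` gives 312 nM. Within the data shown here, the only step measured is a 2.1-fold lower number from compound 1 to compound 2 (0.33 log units; beyond the scatter), which swapped a large group for nitro. Compound 3 `CNc1cc(CNCCCNC2CCCCC2)cc(CNCCCNC2CCCCC2)c1` differs by methylamino in place of nitro on an aromatic carbon. Among the measured compounds shown here, no measured step changes a small group into another small group, so the step of a 1.5-fold higher number from compound 2 to compound 3 (0.18 log units; within the scatter) is expected to stay close to the scatter, with little change in either direction. Compound 3 is therefore estimated at 220 nM, within 70 nM to 700 nM.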

Compound 3, half-maximal inhibitory concentration: 67.6 nM
Beside the measured number, compound 3's estimate is 3.3-fold (0.51 log units) above it; measured number below the stated range.
By their numbers in this assay, from the lowest: compound 3; then compound 2; then compound 1.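

In this assay, swapping one small group for another at this position is not neutral, with a 2.2-fold lower number from compound 2 to compound 3 (0.34 log units; beyond the scatter) as nitro gives way to methylamino. Methylamino also gives a 4.6-fold lower number from compound 1 to compound 3 (0.66 log units; beyond the scatter) in place of the large ((3-(cyclohexylamino)propyl)amino)methyl group, so both small groups shown give lower numbers than that large group. Nothing available explains why methylamino gives the lower number. Going by these compounds, whether the methyl or the hydrogen on the nitrogen matters stays open; a plain amine or a dimethylamino group on this aromatic carbon would help separate the two.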